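Amide nitrogen substituents: from compound 3 to compound 4

A few compounds are considered here, and "the series" means these few. Any claim that something is new, unique, unknown or untested is made for them only; others in the source may bear on it.

In a functional assay on SK-BR-3 cells (Homo sapiens) for cytotoxicity, read by MTT assay, with a stated time of 72 h (a higher number here means a weaker inhibitor, a lower number a stronger inhibitor), compound 1 (`COc1cccc(CNC(=O)c2nc(Br)c3cccnc3c2N[C@H]2CC[C@H](N)CC2)c1`) gives 6000 nM and compound 2 (`N[C@H]1CC[C@H](Nc2c(C(=O)NCc3ccc(F)cc3)nc(Br)c3cccnc23)CC1`) gives 2000 nM while compound 3 (`N[C@H]1CC[C@H](Nc2c(C(=O)NC3CCCCC3)nc(Br)c3cccnc23)CC1`) gives 4200 nM as its value. The cyclohexyl amide is placed by two steps: a 1.4-fold lower number from compound 1 to compound 3 (0.15 log units; within the scatter) stays within the scatter and a 2.1-fold higher number from compound 2 to compound 3 (0.32 log units; beyond the scatter) goes beyond it. Compound 4 (`N[C@H]1CC[C@H](Nc2c(C(=O)NCc3ccccc3)nc(Br)c3cccnc23)CC1`) has benzyl in place of cyclohexyl on an amide-type nitrogen and is not yet measured. The two substituted benzyl amides themselves differ, with a 3.0-fold lower number from compound 1 to compound 2 (0.48 log units; beyond the scatter) between them, so they give no shared direction against the cyclohexyl amide. The expected step is a 1.2-fold lower number from compound 3 to compound 4 (0.08 log units; within the scatter) and is expected to stay within the scatter. Compound 4 is estimated at 3500 nM with 1500 nM to 8000 nM as the expected range.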

Compound 4, half-maximal inhibitory concentration: 8000 nM
Estimate against measurement, compound 4: 2.3-fold (0.36 log units) below; the measured number falls inside the stated range.
By their numbers in this assay, from the lowest: compound 2; then compounds 3, 1 and 4 (each within the scatter of the next).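

On the amide-type nitrogen, the change from a saturated to an aromatic ring with one added carbon gives a 1.9-fold higher number from compound 3 to compound 4 (0.28 log units; within the scatter) and so does not separate the two unsubstituted amides. Among the benzyl amides, hydrogen in place of fluoro gives a 4.0-fold higher number from compound 2 to compound 4 (0.60 log units; beyond the scatter) and lies beyond the scatter, whereas hydrogen in place of methoxy gives a 1.3-fold higher number from compound 1 to compound 4 (0.12 log units; within the scatter) and lies within it. The gain of compound 2 therefore belongs to the fluoro group rather than to the benzyl amide as such.

Still open, going by these compounds, is whether chloro or a longer chain such as phenethyl on this nitrogen would match compound 2. No measurement on hand accounts for the fluoro step.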